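The source may report more compounds than this note shows. Statements on the series, on what has been measured and on what is new or still open speak of the compounds shown alone.

Working notes on the series, read in a functional assay on HeLa cells (Homo sapiens) for cytotoxicity, read by neutral red uptake, with a stated time of 3 days; a higher number here means a weaker inhibitor, a lower number a stronger inhibitor. Compound 1 `Nc1ccc(-c2cc(=O)c3c(N)c(F)cc(F)c3o2)cc1F` gives > 100000 nM, which is a limit of the assay and not a number. Compound 2 `CCCCCCc1c(F)c(N)c2c(=O)cc(-c3ccc(N)c(F)c3)oc2c1F` gives 21000 nM and compound 3 `COc1c(F)c(N)c2c(=O)cc(-c3ccc(N)c(F)c3)oc2c1F` gives 34000 nM. Within the data shown here, these are the only two true numbers so far, and they lie within the scatter of each other.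

Compound 4 `Nc1ccc(-c2cc(=O)c3c(N)c(F)c(N)c(F)c3o2)cc1F` differs from compound 3 at one place: amino in place of methoxy on an aromatic carbon. This is amino in place of methoxy on an aromatic carbon, ortho to two fluoro groups.

Among the measured compounds shown here, three measured steps bear on that carbon. Hexyl in place of hydrogen gives an at least 4.7-fold lower number from compound 1 to compound 2 (0.67 log units; beyond the scatter), and methoxy in place of hydrogen gives an at least 2.9-fold lower number from compound 1 to compound 3 (0.46 log units; beyond the scatter). Both sizes are bounds only. Methoxy in place of hexyl gives a 1.6-fold higher number from compound 2 to compound 3 (0.21 log units; within the scatter). For the measured compounds named here, no measured step carries amino at this place, so the read-across is indirect.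

With two different groups landing close together, compound 4 is expected to stay near compound 3 at 34000 nM, with no change beyond the scatter and perhaps a slight drift to a higher number. A result reported only as a limit remains possible. The expected step is a 1.3-fold higher number from compound 3 to compound 4 (0.12 log units; within the scatter). For compound 4 the estimated value is 45000 nM, with an expected range from 15000 nM to 100000 nM.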

Compound 4, half-maximal inhibitory concentration: 19000 nM
For compound 4 the middle estimate is 2.4-fold (0.37 log units) above the measured one; low and high end bracket the measured number.
By their numbers in this assay, from the lowest: compounds 4, 2 and 3 (each within the scatter of the next). At a limit, above all of these: compound 1.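

With amino at the carbon ortho to two fluoro groups, the series in this assay shows an at least 5.2-fold lower number from compound 1 to compound 4 (0.72 log units; beyond the scatter), so a substituent of 1 heavy atom already stands apart from hydrogen here, as hexyl and methoxy do. Amino itself does not separate from the other two groups, with a 1.8-fold lower number from compound 3 to compound 4 (0.25 log units; within the scatter) and a 1.1-fold lower number from compound 2 to compound 4 (0.04 log units; within the scatter); at this place, neither the hydrogen-bond donor that amino brings nor the difference in size between amino and hexyl gives a step beyond the scatter. Compound 1 gives > 100000 nM, which is a limit of the assay and not a number, so the step to amino is a bound only, as are those to hexyl and methoxy: the limit of > 100000 nM in this assay, at which 1 of the 4 values shown sits.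

The compounds shown leave open whether a carboxylic acid, a hydroxyl group or a dimethylamino group at this carbon would stay level with amino, methoxy and hexyl, or whether one of them would fall back towards compound 1. They also leave open whether a longer chain than hexyl would move the number beyond the scatter.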